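Swapping the aryl group on the amine in an electroshock model

The source may report more compounds than this note shows. Statements on the series, on what has been measured and on what is new or still open speak of the compounds shown alone.

Measured so far in a functional assay on the whole organism (strain albino) with Mus musculus as the target, in the maximal electroshock model, with a stated time of 0.5 h; on this read-out lower numbers stand for an effect already at smaller amounts and higher numbers for an effect only at larger amounts of compound:
compound 1 `Cc1ccc(Nc2nnc(Nc3nc(-c4ccc(Br)cc4)cs3)s2)cc1` gives 100 mg/kg
compound 2 `COc1ccccc1Nc1nnc(Nc2nc(-c3ccc(Br)cc3)cs2)s1` gives 300 mg/kg
compound 3 `Cc1ccc(Nc2nnc(Nc3nc(-c4ccccc4)cs3)s2)cc1` gives 100 mg/kg

Compound 4 `COc1ccccc1Nc1nnc(Nc2nc(-c3ccccc3)cs2)s1` has not been measured. It is made from compound 3 by the change (2-methoxyphenyl in place of 4-methylphenyl on a nitrogen on an aromatic ring). The same change was already made once among the measured compounds, from compound 1 to compound 2, where it is described as 2-methoxyphenyl in place of 4-methylphenyl on a nitrogen on an aromatic ring and produced a 3.0-fold higher number from compound 1 to compound 2 (0.48 log units; beyond the scatter). Compounds 3 and 4 differ from compounds 1 and 2 only in the core, where hydrogen in place of bromo on an aromatic carbon applies; this core change made no change at the digits printed from compound 1 to compound 3 (within the scatter), so the two pairs start from the same level.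

The reasoning rests on a single earlier example, which is thin ground, and the place of the change is the same in both pairs. The step from compound 3 to compound 4 is therefore expected to be a 3.0-fold higher number from compound 3 to compound 4 (0.48 log units; beyond the scatter), about the size of the earlier one. For compound 4 in this assay the expected value is 300 mg/kg, with a plausible range from 100 mg/kg to 1000 mg/kg.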

Compound 4, minimum effective dose: 100 mg/kg
For compound 4 the middle estimate is 3.0-fold (0.48 log units) above the measured one, within the range that was stated.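

On the core without bromo, 2-methoxyphenyl in place of 4-methylphenyl gives no change at the digits printed from compound 3 to compound 4 (within the scatter) in this assay, so the rise seen on the core carrying bromo did not carry over to this core: the same change on two cores in this assay, a 3.0-fold higher number (0.48 log units; beyond the scatter) from compound 1 to compound 2 and no change at the digits printed (within the scatter) from compound 3 to compound 4, 3.0-fold (0.48 log units) apart, beyond the scatter of two such steps

The same result can be read through the other change, since hydrogen in place of bromo gives a 3.0-fold lower number from compound 2 to compound 4 (0.48 log units; beyond the scatter) with the 2-methoxyphenyl group, unlike its effect with the 4-methylphenyl group: the same change on two cores in this assay, no change at the digits printed (within the scatter) from compound 1 to compound 3 and a 3.0-fold lower number (0.48 log units; beyond the scatter) from compound 2 to compound 4, 3.0-fold (0.48 log units) apart, beyond the scatter of two such steps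

These four compounds therefore show that the effect of one change here depends on what else is in the molecule, so a step measured on one core cannot simply be added on another, but with a single pair on each core they do not show why this happens or which behaviour is more typical of the series.

As far as these compounds go, it remains open how a chloro group in place of bromo would behave on the core. The same holds for a longer alkyl chain or an amine in place of the aryl group on the nitrogen.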